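Enlarging the Carbamate Ester of an ATM Inhibitor

The source may hold more compounds than are shown below. What is called first, only, known or untested is meant among the compounds shown, and "the series" means these compounds.

Within the data shown here, compound 2 `COc1cc2ncnc(-n3nc(-c4ccccn4)nc3N)c2cc1OCCCNC(=O)OC(C)C` gives 1000 nM in an assay on MCF7 cells for inhibition of Serine-protein kinase ATM (Homo sapiens), read by immunofluorescence, with a stated time of 1 h (a higher number here means a weaker inhibitor, a lower number a stronger inhibitor), the lower of the two numbers known. Compound 1 `COc1cc2ncnc(-n3nc(-c4ccccn4)nc3N)c2cc1OCCCN1CC(C)OC(C)C1` gives 1600 nM in this assay, and the step of a 1.6-fold lower number from compound 1 to compound 2 (0.20 log units; within the scatter) places the two within the usual scatter. Compound 3 `COc1cc2ncnc(-n3nc(-c4ccccn4)nc3N)c2cc1OCCCNC(=O)OCC(C)(C)C` differs from compound 2 by neopentyl in place of isopropyl on an oxygen next to a carbonyl group. Among the measured compounds shown here, the only measured step exchanges a whole ring for the carbamate and says nothing about enlarging the group on its oxygen, so no shift beyond the scatter is expected. Compound 3 is therefore estimated at 1000 nM, within a range of 400 nM to 2500 nM, an expected step of no change at the digits printed from compound 2 to compound 3 (within the scatter).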

Compound 3, half-maximal inhibitory concentration: 1900 nM
Estimate against measurement, compound 3: 1.9-fold (0.28 log units) below, within the range that was stated.
By their numbers in this assay, from the lowest: compounds 2, 1 and 3 (each within the scatter of the next).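

Neopentyl in place of isopropyl on an oxygen next to a carbonyl group gives a 1.9-fold higher number from compound 2 to compound 3 (0.28 log units; within the scatter) in this assay, so these numbers do not separate the two carbamate esters. The neopentyl carbamate is not separated from the 2,6-dimethylmorpholin-4-yl group either, with a 1.2-fold higher number from compound 1 to compound 3 (0.07 log units; within the scatter). No measurement available here accounts for these numbers.

On these data alone, whether a methyl or phenyl group on this oxygen would give a number beyond the scatter remains open. So does the effect of a free amine in place of the carbamate.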